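This account rests on a few compounds, and the source may have more. Where it says the series, first, only, none or still open, it means among the compounds named here.

Compound 2 `COc1cc(-c2nn(-c3cccc(NC(=O)c4ccc(Cl)c(C(F)(F)F)c4)c3)cc2-c2ccncc2)ccc1Cl` carries an amide made from a 4-chloro-3-(trifluoromethyl)phenyl group. Among the measured compounds shown here, in a functional assay on M14 cells (Homo sapiens) for inhibition, read by sulforhodamine B assay, with a stated time of 48 h (on this read-out lower numbers stand for stronger inhibition of growth and higher numbers for weaker inhibition of growth), compound 2 gives 2790 nM, and its only neighbour among the measured compounds, compound 1, sits within the usual scatter of that number. Compound 1 `COc1cc(-c2nn(-c3cccc(NC(=O)c4cccc(C(F)(F)F)c4)c3)cc2-c2ccncc2)ccc1Cl` differs only by having hydrogen where compound 2 has chloro on that aromatic ring, and in this assay compound 1 gives 1630 nM. For the measured compounds named here, the one measured step, a 1.7-fold higher number from compound 1 to compound 2 (0.23 log units; within the scatter), is small. Compound 3 `COc1cc(-c2nn(-c3cccc(NC(=O)c4ccccc4)c3)cc2-c2ccncc2)ccc1Cl` takes the next step: phenyl in place of 4-chloro-3-(trifluoromethyl)phenyl on a carbonyl carbon. Going by the values given here, this undoes the chloro addition of that measured step and also removes the trifluoromethyl, for which no measured step exists. From the chloro part alone, compound 3 is expected to shift by about a 1.6-fold lower number from compound 2 to compound 3 (0.22 log units; within the scatter), with the trifluoromethyl part adding uncertainty in both directions. Compound 3 is therefore estimated at 1700 nM, with a range from 600 nM to 5000 nM.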

Compound 3, concentration for 50% growth inhibition: 575 nM
Estimate against measurement, compound 3: 3.0-fold (0.47 log units) above; measured number below the stated range.
By their numbers in this assay, from the lowest: compound 3; then compounds 1 and 2 (each within the scatter of the next).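

In this assay the change to plain phenyl on the carbonyl carbon gives a 4.9-fold lower number from compound 2 to compound 3 (0.69 log units; beyond the scatter) and hydrogen in place of trifluoromethyl gives a 2.8-fold lower number from compound 1 to compound 3 (0.45 log units; beyond the scatter) on the same ring. Unlike the chloro step, both of these lie beyond the scatter, so this ring now shows that its substituents can matter, and among these three compounds the unsubstituted phenyl gives the strongest inhibition of growth. No available evidence explains this difference.

Still open, on these data alone, is whether a single chloro on the phenyl, without the trifluoromethyl, would leave the number unchanged as it did in the step with trifluoromethyl present. Also open, as far as these compounds go, is how a methyl, an amine or a carboxylic acid on this phenyl would compare with hydrogen.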